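The source may hold more compounds than are shown below. What is called first, only, known or untested is meant among the compounds shown, and "the series" means these compounds.

Among the compounds with values here, compound 1 `O=C(CCCCCCc1ccccc1)c1ncc(-c2ccc(O)cc2)o1` stands at the higher of the two numbers known in an assay (Rattus norvegicus) for inhibition of Fatty-acid amide hydrolase 1 (Homo sapiens); a lower number here means a stronger inhibitor, a higher number a weaker inhibitor; in this assay compound 1 gives 140 nM. Its companion, compound 2 `COC(=O)c1ccc(-c2cnc(C(=O)CCCCCCc3ccccc3)o2)nc1`, carries a different group on the shared core and gives 3.5 nM in this assay, a far lower number than compound 1 and well beyond the scatter. No change in a single place links these two, so their values only show that the group on that aromatic carbon of the core can move the number a long way. The step followed here leads from compound 1 to compound 3 `O=C(CCCCCCc1ccccc1)c1ncc(C(=O)N2CCOCC2)o1`, not yet measured in this assay. The change is (morpholin-4-yl)carbonyl in place of 4-hydroxyphenyl on an aromatic carbon. Compound 2 with 3.5 nM shows that another group on the core can give a much lower number than compound 1, so a modest move toward a lower number is expected for compound 3. The expected step is a 2.3-fold lower number from compound 1 to compound 3 (0.37 log units; beyond the scatter). For compound 3 the estimate in this assay is 60 nM, with a range from 12 nM to 300 nM.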

Compound 3, inhibition constant: 24 nM
Compound 3: middle estimate off by 2.5-fold (0.40 log units), on the high side; the measured number falls inside the stated range.
By their numbers in this assay, from the lowest: compound 2; then compound 3; then compound 1.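

In this assay, within the data shown here, placing (morpholin-4-yl)carbonyl where 4-hydroxyphenyl stood gives a 5.8-fold lower number from compound 1 to compound 3 (0.77 log units; beyond the scatter) and provides the first reading of a change made in a single place on this aromatic carbon. It shows that a six-membered aromatic ring of carbon only and a hydrogen-bond donor are not required here for a lower number, since a non-aromatic ring with 2 hetero atoms, attached through a carbonyl, gives the lower value in this pair. No measurement shown explains the size or direction of this step.

The compounds shown leave open whether the carbonyl or the morpholine ring goes with the lower number, which a carboxylic acid or a piperidine-1-carbonyl group on the same carbon could separate. They also leave open whether the step persists with a longer chain on the ring atom that bears a large group.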